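This account rests on a few compounds, and the source may have more. Where it says the series, first, only, none or still open, it means among the compounds named here.

Compound 2 `CCCCCNC(=O)CC1CCc2cc(OC)c(OC)cc21` gives 34% in a functional assay on the whole organism (strain Wistar) for inhibition, with Rattus norvegicus as the target, read by paw edema, with stated times of 60 min and 2 h, at a dose of 100 mg/kg by the oral route; on this read-out lower numbers stand for less inhibition and higher numbers for more inhibition at the one dose given (going by the name of the read-out). Going by the values given here, only one other number exists: compound 1 `CCN(CC)C(=O)CC1CCc2cc(OC)c(OC)cc21` gives 40% in this assay, and the step of a number 6 percentage points lower from compound 1 to compound 2 (within the scatter) stays within the scatter, so the two cannot be told apart. Compound 3 `COc1cc2c(cc1OC)C(CC(=O)NC1CCCCC1)CC2` is not yet measured; it differs from compound 2 by cyclohexyl in place of pentyl on an amide-type nitrogen. Among the compounds with values here, the single measured step, also a change on the amide-type nitrogen, was within the scatter, so no move beyond the scatter is expected here either. Compound 3 is therefore estimated at 35%, between 20% and 50%. That estimate means an expected step of a number 1 percentage points higher from compound 2 to compound 3 (within the scatter).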

Compound 3, a percentage reported as inhibition, in the whole organism at one dose (the size of the read-out at that dose, not a potency): 56%
Beside the measured number, compound 3's estimate is 21 percentage points below it; the whole stated range lies below it.
By their numbers in this assay, from the lowest: compounds 2 and 1 (each within the scatter of the next); then compound 3.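

Cyclohexyl in place of pentyl on an amide-type nitrogen gives a number 22 percentage points higher from compound 2 to compound 3 (beyond the scatter) in this assay and so shows that a change at this position can move the read-out beyond the scatter, which the step from diethylamino to pentylamino did not show. Cyclohexylamino in place of diethylamino gives a number 16 percentage points higher from compound 1 to compound 3 (beyond the scatter) and points the same way. Nothing available here accounts for this difference.

From the compounds shown here alone, whether a ring is what matters on this nitrogen remains open. A cyclopentyl or phenyl group there could help to answer that, and a longer chain would test the open-chain side.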